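Cytotoxicity notes on compounds 1 to 4

The source may hold more compounds than are shown below. What is called first, only, known or untested is meant among the compounds shown, and "the series" means these compounds.

Measured so far:
compound 1 `CCOC(=O)Nc1cc(NC(C)CCCN(CC)CC)c2nc(-c3ccco3)c(-c3ccco3)nc2n1` — > 40000 nM
compound 2 `CCOC(=O)Nc1cc(NC(C)CCCN(CC)CC)c2nc(-c3ccccn3)c(-c3ccccn3)nc2n1` — > 40000 nM
compound 3 `CCOC(=O)Nc1cc(NCCCCN(CC)CC)c2nc(-c3ccccc3)c(-c3ccccc3)nc2n1` — 1800 nM

In an ADME assay on Vero cells (Chlorocebus sabaeus) for cytotoxicity, read by CellTiter-Glo, with a stated time of 72 h (on this read-out lower numbers stand for higher toxicity in this test and higher numbers for lower toxicity in this test), compound 1 returns > 40000 nM, which is a limit of the assay and not a number. Compound 2 likewise ends at a limit, > 40000 nM. Compound 3 alone gives a number, 1800 nM. For the measured compounds named here, compound 1 therefore stands together with compound 2 at the limit of > 40000 nM in this assay, at which 2 of the 3 values shown sit, and the one numerical value in the set belongs to compound 3, which carries a different pair of aryl groups and a different chain. Going by the values given here, no pair of measured compounds differs in a single place, so no measured step is available to lean on.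

Compound 4 `CCOC(=O)Nc1cc(NCCN(C)C)c2nc(-c3ccco3)c(-c3ccco3)nc2n1` is still to be measured in this assay. It keeps the furan pair of compound 1 and differs from it in one place:
2-(dimethylamino)ethyl in place of 4-(diethylamino)-1-methylbutyl on a nitrogen on an aromatic ring
Among the compounds with values here, with compound 1 at the limit and no measured step to guide the size, no change beyond the usual scatter is expected; the result for compound 4 is expected to sit again at or near the limit, a step that the limit leaves unreadable from compound 1 to compound 4. The estimated value for compound 4 is 45000 nM, within 15000 nM to 150000 nM.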

Compound 4, half-maximal cytotoxic concentration: 37000 nM
Estimate against measurement, compound 4: 1.2-fold (0.09 log units) above, and the stated range covers the measured number.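

In this assay compound 4 gives 37000 nM, a number rather than a limit, with 2-(dimethylamino)ethyl in place of 4-(diethylamino)-1-methylbutyl and the furan pair kept, and this single-place change reads as an at least 1.0-fold lower number from compound 1 to compound 4 (0.03 log units; that floor lies within the scatter). The value of compound 1, > 40000 nM, is a limit of the assay and not a number. The step is only a floor, and the true size of the change on this nitrogen stays unread because compound 1 stands at a limit: the limit of > 40000 nM in this assay, at which 2 of the 4 values shown sit.

Compound 3 differs from compound 1 in more than one place, so the shares of its aryl pair and its chain in its value remain unseparated. Also open, on these data alone, is how a terminal morpholine, or a longer chain ending in a carboxylic acid, would read on the furan pair.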